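Lengthening the Amide Chain on a Sulfonate Ester Scaffold

This account rests on a few compounds, and the source may have more. Where it says the series, first, only, none or still open, it means among the compounds named here.

Three measured compounds share one core and differ in two places. Compound 1 `CC(=O)Nc1ccc(S(=O)(=O)Oc2ccccc2C(C)C)cc1` gives 16000 nM in a functional assay on MCF7 cells (Homo sapiens) for antiproliferative activity, read by sulforhodamine B assay, with a stated time of 48 h; on this read-out higher numbers stand for weaker inhibition and lower numbers for stronger inhibition. Compound 2 `CC(=O)Nc1ccc(S(=O)(=O)Oc2ccccc2I)cc1` gives 27000 nM, and compound 3 `CCCC(=O)Nc1ccc(S(=O)(=O)Oc2ccccc2I)cc1` gives 9700 nM. Compound 1 stands second highest of the three, but both its neighbours lie within the scatter: a 1.7-fold higher number from compound 1 to compound 2 (0.23 log units; within the scatter), and compound 3 sits within the scatter of compound 1 as well.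

The unmeasured compound 4 `CCCCCC(=O)Nc1ccc(S(=O)(=O)Oc2ccccc2C(C)C)cc1` differs from compound 1 in one place: butyl in place of hydrogen on a saturated chain carbon bound to a carbonyl carbon. The same kind of change is seen once in the measured set: a 2.8-fold lower number from compound 2 to compound 3 (0.44 log units; beyond the scatter). Going by the values given here, that step is the one that bears on compound 4, and it points downward, beyond the scatter, though only modestly. Compound 4 carries a longer chain than compound 3 does, and nothing in the data shows what a butyl rather than an ethyl does at this place, so the expectation rests on that single step alone.

Compound 4 is therefore expected to show a step of a 2.9-fold lower number from compound 1 to compound 4 (0.46 log units; beyond the scatter) in this assay, a drop a little beyond the scatter. The estimate for compound 4 is 5500 nM, with a range from 2000 nM to 15000 nM.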

Compound 4, half-maximal inhibitory concentration: 5300 nM
Compound 4: middle estimate off by 1.0-fold (0.02 log units), on the high side; low and high end bracket the measured number.
By their numbers in this assay, from the lowest: compounds 4, 3, 1 and 2 (each within the scatter of the next, the first and the last beyond it).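

In this assay, going by these compounds alone, adding to the chain at this place now lowers the number on a second version of the core: with isopropyl on the aromatic carbon the result is a 3.0-fold lower number from compound 1 to compound 4 (0.48 log units; beyond the scatter), whereas the only earlier example, a 2.8-fold lower number from compound 2 to compound 3 (0.44 log units; beyond the scatter), came from a compound carrying iodo. Ethyl and butyl in place of hydrogen, each on a saturated chain carbon bound to a carbonyl carbon, therefore point the same way and both lie beyond the scatter, and no compound shown goes against that direction. Nothing shown gives a reason for this shared direction.

Compound 3 and compound 4 differ in two places, so the compounds shown leave open how ethyl and butyl compare on one and the same core. From the compounds shown here alone, it also remains open whether the number would keep falling, level off or rise again with a longer chain such as octyl, or with a phenyl ring, a hydroxyl group or an amine at this same carbon.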